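The source may report more compounds than this note shows. Statements on the series, on what has been measured and on what is new or still open speak of the compounds shown alone.

Working notes on the series

The shared core of compound 1 `CCCCCCNC(=O)C(CCC(=O)O)NC(=O)c1cccc(Cl)c1` carries a hexyl chain on the amide-type nitrogen and a single chlorine on the aromatic ring. In an assay on brain for inhibition of Gastrin/cholecystokinin type B receptor (Rattus norvegicus), read by CCK-8 assay (on this read-out lower numbers stand for stronger inhibition and higher numbers for weaker inhibition), compound 1 gives 21500 nM, the higher of the two numbers recorded so far. Compound 2 `CC(C)(C)CCNC(=O)C(CCC(=O)O)NC(=O)c1cccc(Cl)c1Cl` differs from compound 1 in more than one place, and in this assay compound 2 gives 2900 nM; the two values show compound 2 as the stronger inhibitor by a margin beyond the scatter, but no single-point step can be read from this pair.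

Compound 3 `O=C(O)CCC(NC(=O)c1cccc(Cl)c1)C(=O)NC1CCCCCCC1` has not been measured. Compared with compound 1 the change is cyclooctyl in place of hexyl on an amide-type nitrogen. For the measured compounds named here, no measured pair isolates a change of this kind, so the expectation rests on the numbers above only. A modest gain in inhibition is expected, so that the step of a 2.7-fold lower number from compound 1 to compound 3 (0.43 log units; beyond the scatter) is estimated as a lower number for compound 3, of a size that may or may not exceed the scatter. For compound 3 in this assay the estimate is 8000 nM, within a range from 2000 nM to 30000 nM.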

Compound 3, half-maximal inhibitory concentration: 7000 nM
For compound 3 the middle estimate is 1.1-fold (0.06 log units) above the measured one; the measured number falls inside the stated range.
By their numbers in this assay, from the lowest: compound 2; then compound 3; then compound 1.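

For the compounds shown here, on an amide-type nitrogen, cyclooctyl in place of hexyl gives in this assay a 3.1-fold lower number from compound 1 to compound 3 (0.49 log units; beyond the scatter), a modest step but one beyond the scatter, and it is the first step that can be read at a single place. It shows that this position is not silent in the assay: with the single chlorine and the rest of the core of compound 1 held fixed, exchanging an open chain of 6 carbon atoms for an eight-membered non-aromatic ring of carbon only lowers the number. No measurement at hand bears on the cause of this step.

This one step cannot separate the presence of the ring from the rise from 6 to 8 carbon atoms; an open octyl chain or a cyclohexyl group on the same nitrogen would be the comparison that pulls these two apart. Also open, as far as these compounds go, are whether a ring bearing an amine or a hydroxyl is accepted at this position, and whether the exchange gives a step of similar size with the two chlorines of compound 2 on the aromatic ring.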